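Acetyl removal on the phenolic oxygen: expected effect

The source may hold more compounds than are shown below. What is called first, only, known or untested is meant among the compounds shown, and "the series" means these compounds.

Among the compounds with values here, compound 2 `COc1cc(/C=C/C(=O)OCCSc2nc(-c3ccc(S(C)(=O)=O)cc3)n(-c3ccc(C(F)(F)F)cc3)n2)ccc1OC(C)=O` gives 9650 nM in a functional assay on A549 cells (Homo sapiens) for antiproliferative activity, read by MTT assay, with a stated time of 72 h (a lower number here means a stronger inhibitor, a higher number a weaker inhibitor), the lowest of the two numbers so far; its nearest neighbour, compound 1 `CC(=O)Oc1ccc(/C=C/C(=O)OCCSc2nc(-c3ccc(S(C)(=O)=O)cc3)n(-c3ccc(C(F)(F)F)cc3)n2)cc1OC(C)=O`, gives 10200 nM in this assay. Within the data shown here, the one step in hand, a 1.1-fold lower number from compound 1 to compound 2 (0.02 log units; within the scatter), came from methyl in place of acetyl on an oxygen on an aromatic ring and stayed within the scatter. Compound 3 `COc1cc(/C=C/C(=O)OCCSc2nc(-c3ccc(S(C)(=O)=O)cc3)n(-c3ccc(C(F)(F)F)cc3)n2)ccc1O` carries hydrogen in place of acetyl on an oxygen on an aromatic ring, a change at the same kind of position. From that single step no movement beyond the scatter is expected, so a 1.1-fold lower number from compound 2 to compound 3 (0.03 log units; within the scatter) is the estimated step, and compound 3 is expected to give 9000 nM in this assay, within 4000 nM to 20000 nM.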

Compound 3, half-maximal inhibitory concentration: 6780 nM
For compound 3 the middle estimate is 1.3-fold (0.12 log units) above the measured one, within the range that was stated.
By their numbers in this assay, from the lowest: compounds 3, 2 and 1 (each within the scatter of the next).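

In this assay, the change from 4-acetoxy-3-methoxyphenyl to 4-hydroxy-3-methoxyphenyl gives a 1.4-fold lower number from compound 2 to compound 3 (0.15 log units; within the scatter), so a free hydroxy joins methyl as a second replacement for acetyl on this oxygen that stays within the scatter. The acetyl is therefore not needed to hold the number at this level across these compounds. Nothing available bears on the reason for this result.

The compounds shown leave open whether an ethyl group or a longer chain on this oxygen would move the number beyond the scatter. They also leave open what an amine in place of the hydroxy would do.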